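The source may hold more compounds than are shown below. What is called first, only, known or untested is meant among the compounds shown, and "the series" means these compounds.

Measured so far in a functional assay on VCaP cells (Homo sapiens) for antiproliferative activity, read by propidium iodide staining, with a stated time of 96 h; on this read-out higher numbers stand for weaker inhibition and lower numbers for stronger inhibition:
Compound 1 `CC(O)(CS(=O)(=O)c1ccc(S(F)(F)(F)(F)F)cc1)C(=O)Nc1ccc(S(F)(F)(F)(F)F)cc1`: 15700 nM
Compound 2 `CC(O)(CS(=O)(=O)c1ccccc1C(F)(F)F)C(=O)Nc1ccc(S(F)(F)(F)(F)F)cc1`: 23800 nM

Compound 2 stands at 23800 nM and compound 1 at 15700 nM. This gap lies within the usual scatter of repeated measurements, so the two compounds cannot be ranked.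

The next molecule, compound 3 `CC(O)(CS(=O)(=O)c1ccc(OC(F)(F)F)cc1)C(=O)Nc1ccc(S(F)(F)(F)(F)F)cc1`, differs from compound 2 in one place: it has 4-(trifluoromethoxy)phenyl in place of 2-(trifluoromethyl)phenyl on a sulfonyl sulfur. Among the compounds with values here, no two measured compounds differ in only one place, so no measured step is available as a guide. The only hint is indirect. Compound 1 and compound 2 carry different groups on the sulfonyl sulfur, yet their values stay within the scatter of each other. On this slim evidence, any change in this assay is expected to be small, with no shift beyond the scatter and perhaps a slight drift toward lower numbers. The expected step of a 1.4-fold lower number from compound 2 to compound 3 (0.15 log units; within the scatter) stays within the scatter. For compound 3 the estimated value is 17000 nM, with an expected range from 7000 nM to 38000 nM.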

Compound 3, half-maximal inhibitory concentration: 95800 nM
The estimate for compound 3 lay 5.6-fold (0.75 log units) below the measured number, outside the stated range (above it).
By their numbers in this assay, from the lowest: compounds 1 and 2 (each within the scatter of the next); then compound 3.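

In this assay the group on the sulfonyl sulfur turns out to matter: compound 1 and compound 2 could not be ranked, but 4-(trifluoromethoxy)phenyl in place of 2-(trifluoromethyl)phenyl gives a 4.0-fold higher number from compound 2 to compound 3 (0.60 log units; beyond the scatter) and so moves beyond the scatter toward weaker inhibition. The same direction appears when a trifluoromethoxy group replaces the pentafluorosulfanyl group on an aromatic carbon, with a 6.1-fold higher number from compound 1 to compound 3 (0.79 log units; beyond the scatter) as the result, which makes compound 3 the weakest inhibitor of the three. No measurement shown here accounts for this loss of inhibition.

The step from compound 2 to compound 3 changes both the group on the ring and its printed ring position, so the effects of these two changes cannot be separated. On these data alone, it also remains open how an unsubstituted phenyl, a 4-methoxyphenyl or a 4-aminophenyl on the sulfonyl sulfur would behave, and whether any group there could give clearly stronger inhibition than compound 1 and compound 2 show.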